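The source may hold more compounds than are shown below. What is called first, only, known or untested is meant among the compounds shown, and "the series" means these compounds.

Compound 1, `C=CC1=C(C(=O)Nc2ccccc2OC)C(c2ccc(F)cc2)OC1`, is a member of a small set tested in a functional assay on HeLa cells (Homo sapiens) for cytotoxicity, read by MTT assay, with a stated time of 24 h; on this read-out higher numbers stand for weaker inhibition and lower numbers for stronger inhibition. In this assay compound 1 gives > 100000 nM, which is a limit of the assay rather than a number. Going by the values given here, compound 2, `C=CC1=C(C(=O)Nc2ccc(OCC)cc2)C(c2ccc(OC)cc2)OC1`, is the only other measured compound, and in this assay compound 2 gives > 100000 nM, again a limit. Among the compounds with values here, compound 1 therefore stands exactly where every value shown stands, at the limit of > 100000 nM in this assay, at which 2 of the 2 values shown sit, so no step between measured compounds can be read. Compound 3, `C=CC1=C(C(=O)NCc2ccccc2)C(c2ccc(F)cc2)OC1`, is not yet measured and differs from compound 1 by benzyl in place of 2-methoxyphenyl on an amide-type nitrogen, a benzyl in place of a 2-methoxyphenyl on the amide-type nitrogen. Because both values shown sit at the limit of > 100000 nM in this assay, at which 2 of the 2 values shown sit, the step from compound 1 to compound 3 is expected to be none beyond the scatter, most likely ending at the limit again. Compound 3 is expected to give about 150000 nM, within a range from 40000 nM to 600000 nM. The expected step is a step that the limit leaves unreadable from compound 1 to compound 3.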

Compound 3, half-maximal inhibitory concentration: > 100000 nM
Compound 3: no number, only a limit; the forecaster's own chance of this, stated with the estimate: 80%; the middle value does not contradict the limit.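

Like compound 1, compound 3 returns only a limit in this assay, so no step between compound 1 and compound 3 can be read: the limit of > 100000 nM in this assay, at which 3 of the 3 values shown sit. The compounds shown leave open whether any change on the amide-type nitrogen would give a measurable half-maximal inhibitory concentration.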